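A cyano group replaces a three-atom group

The source may report more compounds than this note shows. Statements on the series, on what has been measured and on what is new or still open speak of the compounds shown alone.

Values measured in a functional assay on HeLa cells (Homo sapiens) for antiproliferative activity, read by cell counting, with a stated time of 4 days (on this read-out lower numbers stand for stronger inhibition and higher numbers for weaker inhibition), are these.
Compound 1 `CCOC(=O)C(=O)N(Cc1ccccc1)c1ccc2c(c1)OC(C)(CO)CN2C` gives > 100000 nM (a limit of the assay)
Compound 2 `CCOC(=O)CN(Cc1cc(F)cc(F)c1)c1ccc2c(c1)N(C)CC(C)(COc1ccc(C#N)cc1)O2` gives > 100000 nM (a limit of the assay)
Compound 3 `CCOC(=O)CN(Cc1cccc(F)c1)c1ccc2c(c1)N(C)CC(C)(COc1ccc(C(=N)N)cc1)O2` gives 4600 nM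

Compound 3 is the only one of the three with a true number, and it stands against two limits. The step to compound 4 `CCOC(=O)CN(Cc1cccc(F)c1)c1ccc2c(c1)N(C)CC(C)(COc1ccc(C#N)cc1)O2` is a group of 2 heavy atoms (1 carbon, 1 nitrogen; no ring) in place of a group of 3 heavy atoms (1 carbon, 2 nitrogen; no ring), on an aromatic carbon and it falls on an aromatic carbon, para to a large group. Going by the values given here, no measured step gives its size directly. Compound 2 also carries cyano and sits at > 100000 nM as a limit of this assay here. On that basis the expected change is a 15-fold higher number from compound 3 to compound 4 (1.18 log units; beyond the scatter) toward weaker inhibition, beyond the usual scatter. The estimate for compound 4 is 70000 nM with an expected range of 20000 nM to 100000 nM in this read-out, and the assay may well report only a limit.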

Compound 4, half-maximal inhibitory concentration: > 100000 nM
Compound 4 ended at the assay's limit; the forecaster's own chance of this, stated with the estimate: 75%; middle value at least 1.4-fold (0.15 log units) away from the limit.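

In this assay, cyano in place of the three-atom group on this aromatic carbon, para to a large group, gives an at least 21-fold higher number from compound 3 to compound 4 (1.33 log units; beyond the scatter), showing that this single change is enough to remove the measurable value of compound 3. Compound 4 gives > 100000 nM, which is a limit of the assay. The true size of that step stays unknown, and the step between compound 2 and compound 4 cannot be read: the limit of > 100000 nM in this assay, at which 3 of the 4 values shown sit.

The compounds shown leave open whether an aminomethyl group or a carboxylic acid on this aromatic carbon would give a measurable value in this assay.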